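A few compounds are considered here, and "the series" means these few. Any claim that something is new, unique, unknown or untested is made for them only; others in the source may bear on it.

Compound 1, `Cc1cccc(-c2cccc(NCc3cncn3Cc3ccccc3)c2)c1C`, was tested in a toxicity assay on NIH3T3 cells (Mus musculus) for cytotoxicity, read by resazurin assay; on this read-out higher numbers stand for an effect only at larger amounts of compound and lower numbers for an effect already at smaller amounts. For compound 1 the read-out is a limit rather than a number, namely > 1000 nM. Compound 2, `c1ccc(-c2ccc(Cn3cncc3CNc3ccc(-c4ccc[nH]4)c(-c4ccccc4)c3)cc2)cc1`, likewise gives only a limit in this assay, namely > 10000 nM. One of the two values shown thus sits at the limit of > 1000 nM in this assay, at which 1 of the 2 values shown sits. Going by the values given here, the other sits at the limit of > 10000 nM in this assay, at which 1 of the 2 values shown sits, and this is where compound 2 stands, at the higher of the two limits; with both values being limits, no step between measured compounds can be given. Compound 3, `CCCC(=O)c1ccc(NCc2cncn2Cc2ccc(-c3ccccc3)cc2)cc1-c1ccccc1`, has not yet been measured in this assay. It differs from compound 2 in a single place: propylcarbonyl in place of 1H-pyrrol-2-yl on an aromatic carbon. The rest of compound 2 stays untouched. As compound 2 sits at the limit of > 10000 nM in this assay, at which 1 of the 2 values shown sits, compound 3 is expected to behave in much the same way, and the expected step that the limit leaves unreadable from compound 2 to compound 3 is none beyond the usual scatter. For compound 3 in this assay the estimated value is 15000 nM, with a range from 3000 nM to 60000 nM, and it is expected that the read-out will again be reported only as a limit.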

Compound 3, half-maximal effective concentration: > 10000 nM
Compound 3 was reported as a limit (the forecaster's own chance of this, stated with the estimate: 85%); the middle value lies beyond the limit too.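

In this assay compound 3 gives only a limit, > 10000 nM. Compound 2 also stands at a limit, so no step can be read from compound 2 to compound 3 for propylcarbonyl in place of 1H-pyrrol-2-yl. The compounds shown leave open whether this exchange changes the read-out at all, since none of them gives an actual number.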